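The compounds below may be only part of what the source reports. "The series", "measured", "known", "first", "only" and "open" are said of these compounds alone.

Two compounds here share one core, and a third is built from the second. Going by the values given here, compound 2 `Cc1nn([C@H](C)c2ccc(Cl)cc2Cl)c2nc(N3CC[C@H](N4CCC[C@H]4CCC(N)=O)[C@H](C)C3)cnc12` is the only one with a number: in an assay on CCRF-CEM cells for antagonist activity at C-C chemokine receptor type 4 (Homo sapiens), read by CellTiter-Glo, with stated times of 30 min and 60 min, in the presence of a further agent that is not named here (on this read-out higher numbers stand for weaker inhibition and lower numbers for stronger inhibition), compound 2 gives 355 nM. Compound 1 `Cc1nn([C@H](C)c2ccc(Cl)cc2Cl)c2nc(N3CC[C@H](N4CCCC4)[C@H](C)C3)cnc12` carries the same core, but in this assay compound 1 gives "not determined" (no result reported), so compound 2 stands alone, with nothing to rank it against. Compound 3 `Cc1nn([C@H](C)c2ccc(Cl)cc2Cl)c2nc(N3CC[C@H](N4CCC[C@H]4CCC#N)[C@H](C)C3)cnc12` is the new compound. It differs from compound 2 in one place: cyano in place of carbamoyl on a saturated chain carbon, two bonds along the chain from a saturated ring carbon. Among the compounds with values here, no measured pair shows what this exchange does, so its effect is open. Within the data shown here, with no step to lean on, the change is expected to move the inhibitory concentration only a little, in no direction beyond the usual scatter, and the estimated step is a 1.1-fold higher number from compound 2 to compound 3 (0.05 log units; within the scatter). Compound 3 is therefore expected to give about 400 nM in this assay, with an estimated range from 120 nM to 1300 nM.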

Compound 3, half-maximal inhibitory concentration: 865 nM
Estimate against measurement, compound 3: 2.2-fold (0.33 log units) below, and the stated range covers the measured number.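

In this assay, replacing carbamoyl with cyano on the saturated chain carbon gives a 2.4-fold higher number from compound 2 to compound 3 (0.39 log units; beyond the scatter). Going by these compounds alone, this is the first sign that the group at this position matters, as a higher number here means weaker inhibition. The step is modest, so the 2-(2-cyanoethyl)pyrrolidin-1-yl compound still gives a measurable inhibition, but the 2-(2-carbamoylethyl)pyrrolidin-1-yl group of compound 2 is the better of the two.

From the compounds shown here alone, it remains open how an amine or a carboxylic acid at this place, or a longer chain, would compare, and what the chain itself contributes, as compound 1, which lacks it, gives "not determined" (no result reported) in this assay. Nothing shown here explains why the number rises with this exchange.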